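The source may report more compounds than this note shows. Statements on the series, on what has been measured and on what is new or still open speak of the compounds shown alone.

Working notes on the series. For the measured compounds named here, compound 2 `FC(F)(F)c1cc(COCC2(c3ccccc3)CCC(N3CCCC3)CC2)cc(C(F)(F)F)c1` gives 120 nM in an assay on isolated protein for antagonist activity at Substance-P receptor (Homo sapiens) (a higher number here means a weaker inhibitor, a lower number a stronger inhibitor), the highest of the three numbers so far. Going by the values given here, compound 1 `CCN(CC)C1CCC(COCc2cc(C(F)(F)F)cc(C(F)(F)F)c2)(c2ccccc2)CC1` gives 38 nM, and a 3.2-fold higher number from compound 1 to compound 2 (0.50 log units; beyond the scatter) is the only single-place step in hand. Among the compounds with values here, compound 3 `FC(F)(F)c1cc(COCC2(c3ccccc3)CCC(N3CCCC3)C2)cc(C(F)(F)F)c1` gives 14 nM; its core differs from that of compound 2, so no single-place step links them.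

The next compound, compound 4 `CN1CCN(C2CCC(COCc3cc(C(F)(F)F)cc(C(F)(F)F)c3)(c3ccccc3)CC2)CC1`, differs from compound 2 by 4-methylpiperazin-1-yl in place of pyrrolidin-1-yl on a saturated ring carbon. Within the data shown here, only the step from compound 1 to compound 2 bears on this, since it also exchanged the amine on the same saturated ring carbon, and it was modest. Among the measured compounds shown here, no measured step involves 4-methylpiperazin-1-yl, so the direction is uncertain. Compound 4 is therefore expected near compound 2, with the step of a 1.3-fold higher number from compound 2 to compound 4 (0.10 log units; within the scatter) estimated as small. The estimate for compound 4 in this assay is 150 nM, within 40 nM to 600 nM.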

Compound 4, half-maximal inhibitory concentration: 120 nM
Beside the measured number, compound 4's estimate is 1.3-fold (0.10 log units) above it; the measured number falls inside the stated range.
By their numbers in this assay, from the lowest: compound 3; then compound 1; then compounds 2 and 4 (each within the scatter of the next).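

In this assay there is no change at the digits printed from compound 2 to compound 4 (within the scatter) so on this saturated ring carbon 4-methylpiperazin-1-yl and pyrrolidin-1-yl cannot be told apart. Measured against diethylamino, there is a 3.2-fold higher number from compound 1 to compound 4 (0.50 log units; beyond the scatter) and also a 3.2-fold higher number from compound 1 to compound 2 (0.50 log units; beyond the scatter) so the two ring amines stand on the same side of diethylamino by the same printed size. No supporting data accompany these numbers to explain this. Going by these compounds, whether morpholin-4-yl or dimethylamino on this carbon would read with diethylamino or with the ring amines stays open. Also open, on these data alone, is whether 4-methylpiperazin-1-yl matches pyrrolidin-1-yl on the core of compound 3.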